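This account rests on a few compounds, and the source may have more. Where it says the series, first, only, none or still open, it means among the compounds named here.

Measured so far in a functional assay on MGC-803 cells (Homo sapiens) for inhibition, read by MTT assay, with a stated time of 72 h; on this read-out higher numbers stand for weaker inhibition and lower numbers for stronger inhibition:

- Compound 1 `CCN1CCN(c2cc(C(F)(F)F)nc(SCc3ccc(C(F)(F)F)cc3)n2)CC1`: 25600 nM
- Compound 2 `FC(F)(F)c1ccc(CSc2nc(N3CCN(c4ccccn4)CC3)cc(C(F)(F)F)n2)cc1`: 23500 nM
- Compound 3 `FC(F)(F)c1ccc(CSc2nc(N3CCN(c4ncccn4)CC3)cc(C(F)(F)F)n2)cc1`: 35200 nM

Compound 1 stands close to both of the others. The results show a 1.1-fold lower number from compound 1 to compound 2 (0.04 log units; within the scatter) and a 1.4-fold higher number from compound 1 to compound 3 (0.14 log units; within the scatter), so these numbers do not separate the compounds. The remaining comparison, a 1.5-fold higher number from compound 2 to compound 3 (0.18 log units; within the scatter), is no different.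

Compound 4 `FC(F)(F)c1ccc(CSc2nc(Sc3ccccn3)cc(C(F)(F)F)n2)cc1` has not yet been measured. It keeps the core of compound 1 but carries one change on an aromatic carbon: (pyridin-2-yl)sulfanyl in place of 4-ethylpiperazin-1-yl on an aromatic carbon.

The three measured steps bear on this change only indirectly. Each swaps the group on an amine nitrogen in a ring, while the ring itself stays in place. Among the compounds with values here, compound 4 loses that ring altogether, and no measured compound shows what such a replacement does. The pyridin-2-yl group does occur in compound 2, at 23500 nM, but it is attached differently there.

With only small steps to go on, no shift beyond the scatter is expected in this assay, and no direction can be favoured. The expected outcome is a 1.2-fold lower number from compound 1 to compound 4 (0.07 log units; within the scatter). The untested replacement calls for a wide range. For compound 4 the estimated value is 22000 nM, with an expected range from 7000 nM to 60000 nM.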

Compound 4, half-maximal inhibitory concentration: > 50000 nM
Compound 4 ended at the assay's limit; the forecaster's own chance of this, stated with the estimate: 10%; middle value at least 2.2-fold (0.35 log units) from the limit.
By their numbers in this assay, from the lowest: compounds 2, 1 and 3 (each within the scatter of the next). At a limit, above all of these: compound 4.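

In this assay compound 4 gives > 50000 nM, which is a limit of the assay and not a number: the limit of > 50000 nM in this assay, at which 1 of the 4 values shown sits. Swapping 4-ethylpiperazin-1-yl for (pyridin-2-yl)sulfanyl on this aromatic carbon gives an at least 1.9-fold higher number from compound 1 to compound 4 (0.29 log units; that floor lies within the scatter) and that figure is only a floor, so the real gap could be larger but cannot be read from these data. Within the data shown here, the earlier compounds changed only the group on the ring nitrogen while the non-aromatic ring stayed in place, so this is the first view of what happens when that ring leaves the position, and the change brings no stronger inhibition here.

This single change removes the non-aromatic ring and brings in both a sulfur link and an aromatic ring, so the compounds shown cannot tell which of these parts matters. A simple amine such as morpholine at this position, or a pyridin-2-yl group joined through an amine nitrogen instead of sulfur, would help separate the loss of the ring from the effect of the sulfur link.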